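The source may report more compounds than this note shows. Statements on the series, on what has been measured and on what is new or still open speak of the compounds shown alone.

Measured compounds:
compound 1 `CCOC(=O)c1sc(-c2cccc(NC(=O)c3ccc(Cl)cc3)c2)nc1Nc1ccc(N2CCN(C)CC2)cc1`, "not determined" (no result reported)
compound 2 `CCOC(=O)c1sc(-c2cccc(NC(=O)c3ccc(F)c(Cl)c3)c2)nc1Nc1ccc(N2CCN(C)CC2)cc1`, 29200 nM
compound 3 `CCOC(=O)c1sc(-c2cccc(NC(=O)c3ccco3)c2)nc1Nc1ccc(N2CCN(C)CC2)cc1`, "not determined" (no result reported)

Compound 3 has no number in a functional assay on Ramos cells (Homo sapiens) for antiproliferative activity, read by CCK-8 assay, with a stated time of 72 h; on this read-out lower numbers stand for stronger inhibition and higher numbers for weaker inhibition; it is one of two entries, with compound 1, that were not determined, so it cannot be placed against compound 2. Compound 4 `CN1CCN(c2ccc(Nc3nc(-c4cccc(NC(=O)c5ccco5)c4)sc3C(N)=O)cc2)CC1` differs from compound 3 by the change (amino in place of ethoxy on a carbonyl carbon). Among the measured compounds shown here, no step between measured compounds is known for this change, so the expectation rests on compound 2 alone, which is weak in this assay. The step from compound 3 to compound 4 is expected to be none beyond the scatter, in either direction. Compound 4 is therefore estimated at 25000 nM, within a range from 4000 nM to 100000 nM.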

Compound 4, half-maximal inhibitory concentration: 19700 nM
Compound 4: middle estimate off by 1.3-fold (0.10 log units), on the high side; measured number inside the range.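

In this assay, among the compounds shown here, compound 3 has no single number, and no step to compound 4 can be read. The compounds shown leave open how ethoxy and amino on the carbonyl carbon compare. No evidence bears on this result.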